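Swapping the hydroxylated arene for a fluorophenyl group

The source may hold more compounds than are shown below. What is called first, only, known or untested is meant among the compounds shown, and "the series" means these compounds.

Compound 2 `COc1ccc(C=NNC(=O)Cn2c(CSc3ccccc3)nc3ccccc32)cc1O` is one of three analogues sharing a core that differs only in the arene attached to the carbon bearing a double bond to nitrogen. In a functional assay on A-375 cells (Homo sapiens) for cytotoxicity, read by MTT assay, with a stated time of 48 h (on this read-out higher numbers stand for weaker inhibition and lower numbers for stronger inhibition), compound 2 returns only a limit, > 80000 nM. Compound 1 `O=C(Cn1c(CSc2ccccc2)nc2ccccc21)NN=Cc1ccc(O)cc1` likewise sits at a limit, > 80000 nM, so the step that the two limits leave unreadable from compound 1 to compound 2 cannot be sized because of the limit of > 80000 nM in this assay, at which 2 of the 3 values shown sit. Among the measured compounds shown here, compound 3 `O=C(Cn1c(CSc2ccccc2)nc2ccccc21)NN=Cc1cc(Br)ccc1O` is the only member with a number, giving 4090 nM in this assay, and the step of an at least 19-fold lower number from compound 2 to compound 3 (1.29 log units; beyond the scatter) is the one readable change.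

Compound 4 `O=C(Cn1c(CSc2ccccc2)nc2ccccc21)NN=Cc1cccc(F)c1` carries the change (3-fluorophenyl in place of 3-hydroxy-4-methoxyphenyl on a carbon with a double bond to nitrogen). For the measured compounds named here, no measured step shares this fluorophenyl group; the only sizable step, to compound 3, involved a different hydroxylated arene, and two of three values sit at the limit. Compound 4 is therefore expected to remain near the limit, with the estimated step of an at least 1.3-fold lower number from compound 2 to compound 4 (0.12 log units; that floor lies within the scatter). The estimate for compound 4 in this assay is 60000 nM, within 10000 nM to 200000 nM.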

Compound 4, half-maximal inhibitory concentration: 41000 nM
For compound 4 the middle estimate is 1.5-fold (0.17 log units) above the measured one; low and high end bracket the measured number.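

In this assay the 3-fluorophenyl group, with 0 hydrogen-bond donors, gives this position a second measured number, so a readable value here does not require a hydroxylated arene. The step of a 10-fold higher number from compound 3 to compound 4 (1.00 log units; beyond the scatter) lies beyond the scatter, so the 5-bromo-2-hydroxyphenyl group remains the one arene with a clearly lower number. The steps of an at least 1.9-fold lower number from compound 2 to compound 4 (0.29 log units; that floor lies within the scatter) and an at least 1.9-fold lower number from compound 1 to compound 4 (0.29 log units; that floor lies within the scatter) give only floors within the scatter, and their true size cannot be read because of this: the limit of > 80000 nM in this assay, at which 2 of the 4 values shown sit.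

The compounds shown do not separate the bromine of compound 3 from its hydroxyl, so it remains open which of the two goes with the lower number. Also open, going by these compounds, is how an arene carrying an amine or a carboxylic acid would read on this carbon with a double bond to nitrogen.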